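Dropping the Methyl from the Core Nitrogen

The source may hold more compounds than are shown below. What is called first, only, known or untested is meant among the compounds shown, and "the series" means these compounds.

Compound 1 `CN1c2cc(-c3ccncc3)sc2C(=O)NC1(C)C` gives 140 nM in an assay for inhibition of Rho-associated protein kinase 1 (Homo sapiens), read by TR-FRET, with stated times of 5 min and 2 h; a higher number here means a weaker inhibitor, a lower number a stronger inhibitor. Its closest neighbour is compound 3 `CN1c2cc(-c3cn[nH]c3)sc2C(=O)NC1(C)C`, which gives 130 nM in this assay; the step of a 1.1-fold lower number from compound 1 to compound 3 (0.03 log units; within the scatter) swaps one aromatic group for another and is not a real change. Compound 2 `Cc1n[nH]cc1-c1cc2c(s1)C(=O)N[C@]1(CC[C@](O)(C3CCCCC3)CC1)N2`, built on a different, spiro-fused frame, gives 2900 nM in this assay, a much higher number. Among the three, compound 1 therefore stands second highest, with compound 3 alongside it and compound 2 far above.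

Compound 4 `CC1(C)NC(=O)c2sc(-c3ccncc3)cc2N1` differs from compound 1 in one way: hydrogen in place of methyl on a nitrogen on an aromatic ring in a ring. Within the data shown here, no measured pair here isolates this change. Among the measured compounds shown here, the only measured step, from compound 1 to compound 3, concerns a different part of the molecule and lies within the scatter. Compound 2 does carry a hydrogen on its ring nitrogen, but it differs in several other places, so its number cannot be attributed to that one feature. For the measured compounds named here, with no guiding step, compound 4 is expected to show a 1.1-fold higher number from compound 1 to compound 4 (0.06 log units; within the scatter). Compound 4 is estimated at 160 nM, within a range from 50 nM to 500 nM.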

Compound 4, half-maximal inhibitory concentration: 90 nM
Estimate against measurement, compound 4: 1.8-fold (0.25 log units) above; the range from low to high includes it.
By their numbers in this assay, from the lowest: compounds 4, 3 and 1 (each within the scatter of the next); then compound 2.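

Among these compounds, the step of a 1.6-fold lower number from compound 1 to compound 4 (0.19 log units; within the scatter) is the first reading at this position, the nitrogen on the aromatic ring, and it leaves compound 1 and compound 4 indistinguishable in this assay. With the pyridin-4-yl group in place, the methyl on this nitrogen is therefore not required for a number of this size, and a bare hydrogen serves as well. Nothing measured here explains why the two compounds sit so close.

The compounds shown leave open whether a longer chain on this nitrogen, such as ethyl or propyl, or an acetyl group, would give a similar number in this assay or a clearly different one. On these data alone, it also remains open whether hydrogen in place of methyl reads the same when the 1H-pyrazol-4-yl group of compound 3 is present.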